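The source may report more compounds than this note shows. Statements on the series, on what has been measured and on what is new or still open speak of the compounds shown alone.

Measured so far:
compound 1 `O=C(NC(=S)Nc1ccc(F)cc1)c1cn(-c2ccccc2)nc1-c1ccccc1`; in a functional assay on A549 cells (Homo sapiens) for inhibition, read by CCK-8 assay, with a stated time of 48 h (a lower number here means a stronger inhibitor, a higher number a weaker inhibitor), compound 1 gives 3500 nM.
compound 2 `O=C(NC(=S)Nc1ccc(Cl)cc1)c1cn(-c2ccccc2)nc1-c1ccc(F)cc1`; in this assay compound 2 gives 2990 nM.

Compound 2 holds the lower of the two numbers in this assay; its nearest neighbour is compound 1, and the gap between them lies within the scatter, so no order follows from it. Compound 3 `O=C(NC(=S)Nc1ccc(F)cc1)c1cn(-c2ccccc2)nc1-c1ccc(F)cc1` differs from compound 2 in one place: fluoro in place of chloro on an aromatic carbon. Among the compounds with values here, no step between measured compounds covers this change, so the series gives no size for it. The number in this assay is expected to move little, if at all, beyond the scatter, with the expected step being a 1.2-fold higher number from compound 2 to compound 3 (0.07 log units; within the scatter). For compound 3 the estimate in this assay is 3500 nM, in the range 1500 nM to 8000 nM.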

Compound 3, half-maximal inhibitory concentration: 3540 nM
Estimate against measurement, compound 3: 1.0-fold (0.00 log units) below, and the stated range covers the measured number.
By their numbers in this assay, from the lowest: compounds 2, 1 and 3 (each within the scatter of the next).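

In this assay, (4-chlorophenyl)amino to (4-fluorophenyl)amino gives a 1.2-fold higher number from compound 2 to compound 3 (0.07 log units; within the scatter). Fluoro in place of hydrogen on an aromatic carbon gives a 1.0-fold higher number from compound 1 to compound 3 (0.00 log units; within the scatter), so neither single-place difference separates its pair at this level of scatter. No measurement on hand bears on the reason for this result. Open, going by these compounds, is whether a group of another kind at the position para to a large group, such as an amine, a carboxylic acid or a longer alkyl chain, would move the number beyond the scatter.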